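Another Fluoro on the Core of Compound 2

A few compounds are considered here, and "the series" means these few. Any claim that something is new, unique, unknown or untested is made for them only; others in the source may bear on it.

Three hydroxamic acids were tested in an assay on Sf9 cells for inhibition of protein deacetylase HDAC6 (Homo sapiens), read by fluorescence; a higher number here means a weaker inhibitor, a lower number a stronger inhibitor. Compound 1 `Cc1ccc(C(=O)NO)cn1` gives 70 nM, compound 2 `Cc1ccc(C(=O)NO)cc1F` gives 49 nM, and compound 3 `CC(=O)Nc1ccc(C(=O)NO)cc1` gives 162 nM. Compound 2 shows the lowest of these three numbers: its gap to compound 1 lies within the scatter of repeated measurements, while its gap to compound 3 lies beyond it. Compound 4 `Cc1c(F)cc(C(=O)NO)cc1F` has not yet been measured in this assay. It differs from compound 2 by fluoro in place of hydrogen on an aromatic carbon. Within the data shown here, no measured pair differs in a single place, and the earlier numbers give no direct guide to such a step. The expected step of a 1.2-fold lower number from compound 2 to compound 4 (0.07 log units; within the scatter) is small, with no direction beyond the scatter. Compound 4 is estimated at 42 nM, within a range from 15 nM to 120 nM.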

Compound 4, half-maximal inhibitory concentration: 27 nM
Estimate against measurement, compound 4: 1.6-fold (0.19 log units) above; the measured number falls inside the stated range.
By their numbers in this assay, from the lowest: compounds 4, 2 and 1 (each within the scatter of the next, the first and the last beyond it); then compound 3.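

Fluoro in place of hydrogen on this aromatic carbon, ortho to a methyl group and meta to a fluoro group, gives a 1.8-fold lower number from compound 2 to compound 4 (0.26 log units; within the scatter). Among these compounds, this is the first single-place step, and it shows that a second fluoro on the core is tolerated at this position, with no change beyond the scatter. Nothing at hand bears on why the step has this size.

The compounds shown leave open whether chloro, a methoxy group or an amine at this position would give a step beyond the scatter. They also leave open whether a longer chain in place of the methyl group would do so.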